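The compounds below may be only part of what the source reports. "The series", "measured", "known", "first", "only" and "open" are said of these compounds alone.

Compound 3, `Cc1ccccc1C(=O)c1ccn(-c2ccc3c(c2)B(O)OC3)c1`, is the starting point of the step considered here. In an ADME assay on L929 cells (Mus musculus) for cytotoxicity, read by resazurin assay, with a stated time of 72 h (a lower number here means a stronger inhibitor, a higher number a weaker inhibitor), compound 3 gives > 10 ug/mL, which is a limit of the assay rather than a number. The two compounds measured beside it share its core and differ only on the carbonyl carbon. Compound 1, `CC(=O)c1ccn(-c2ccc3c(c2)B(O)OC3)c1`, gives > 10 ug/mL in this assay, again a limit. Compound 2, `O=C(c1ccc(Cl)cc1)c1ccn(-c2ccc3c(c2)B(O)OC3)c1`, gives > 10 ug/mL in this assay, also a limit. Because of the limit of > 10 ug/mL in this assay, at which 3 of the 3 values shown sit, none of the three values can be placed relative to another, so the steps a step that the two limits leave unreadable from compound 1 to compound 2, a step that the two limits leave unreadable from compound 1 to compound 3 and a step that the two limits leave unreadable from compound 2 to compound 3 remain unreadable in size; each swaps one group on the carbonyl carbon without revealing any effect.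

Compound 4, `CCCCCC(=O)c1ccn(-c2ccc3c(c2)B(O)OC3)c1`, carries the change (pentyl in place of 2-methylphenyl on a carbonyl carbon). The measured steps that bear on it are the three unreadable swaps on the same carbonyl carbon, which set no expectation of a shift in either direction beyond the scatter. Within the data shown here, since every compound so far has sat at the limit, compound 4 is expected to sit there as well, with an estimated step that the limit leaves unreadable from compound 3 to compound 4. For compound 4 in this assay the estimate is 20 ug/mL, expected to fall between 8 ug/mL and 60 ug/mL.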

Compound 4, half-maximal inhibitory concentration: > 10 ug/mL
Compound 4 ended at the assay's limit (the forecaster's own chance of this, stated with the estimate: 80%); the middle value lies beyond the limit too.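

No new step can be read between compound 4 and compound 1, compound 2 or compound 3, because all four compounds sit at one limit: the limit of > 10 ug/mL in this assay, at which 4 of the 4 values shown sit.

The compounds shown leave open whether the methyl, 4-chlorophenyl, 2-methylphenyl and pentyl groups on the carbonyl carbon differ at all in this assay.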